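The compounds below may be only part of what the source reports. "The series", "measured", "known", "first", "only" and "open" are said of these compounds alone.

Compound 1 `COc1cc(COc2ccc(OC)cc2CCCNC(C)=O)cc(OC)c1` gives 0.0326 nM in an assay on CHO cells for displacement of a labelled ligand from melatonin receptor type 1B (Homo sapiens), read by scintillation counting, with a stated time of 60 min; a higher number here means a weaker inhibitor, a lower number a stronger inhibitor.
Compound 2 `COc1cccc(COc2ccc(OC)cc2CCCNC(C)=O)c1` gives 0.00069 nM in this assay.
Compound 3 `COc1cc(CCCNC(C)=O)ccc1OCc1ccccc1` gives 69.3 nM in this assay.

Compound 2 and compound 1 differ in one place only: methoxy in place of hydrogen on an aromatic carbon. That change made the step of a 47-fold higher number from compound 2 to compound 1 (1.67 log units; beyond the scatter), so the added methoxy weakened binding markedly. Compound 3 has a different core from compound 2; the difference between the two cores is not broken down here, and compound 3 gives the highest number of the three.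

Compound 4 `COc1cccc(COc2ccc(CCCNC(C)=O)cc2OC)c1` has not yet been measured. It differs from compound 3 by methoxy in place of hydrogen on an aromatic carbon. Among the compounds with values here, this is the same kind of change as the one from compound 2 to compound 1, but not the same: in compound 1 the place is also meta to a methoxy group, whereas in compound 4 the ring that receives the methoxy carries no other methoxy. Because the step of a 47-fold higher number from compound 2 to compound 1 (1.67 log units; beyond the scatter) came from a second methoxy on an already substituted ring, it is only a loose guide here. Compound 4 is expected to give 60 nM in this assay, with a likely range from 10 nM to 400 nM. This estimate means an expected step of a 1.2-fold lower number from compound 3 to compound 4 (0.06 log units; within the scatter), a much smaller move than the measured one.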

Compound 4, inhibition constant: 105 nM
Estimate against measurement, compound 4: 1.8-fold (0.24 log units) below; the measured number falls inside the stated range.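

On the core of compound 3, adding the methoxy gives a 1.5-fold higher number from compound 3 to compound 4 (0.18 log units; within the scatter) and so moves the number no further than repeated measurements of the same compound might. The size of this step therefore did not carry over from one core to the other in this assay, where the same change was large on the core of compound 2 and small on the core of compound 3: the same change on two cores in this assay, a 47-fold higher number (1.67 log units; beyond the scatter) from compound 2 to compound 1 and a 1.5-fold higher number (0.18 log units; within the scatter) from compound 3 to compound 4, 31-fold (1.49 log units) apart, beyond the scatter of two such steps. Within the data shown here, this rests on only two pairs and does not show why the steps differ, and the core is not the only difference between them, since the ring receiving the methoxy already carries one in compound 2 but none in compound 3.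

The compounds shown leave open how the methoxy step would read on a third core, so no general rule for this change can be drawn from them. They also leave open whether another group in the same place, such as a hydroxyl, an ethoxy or a fluorine atom, would give steps that differ between these two cores.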